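The source may report more compounds than this note shows. Statements on the series, on what has been measured and on what is new or still open speak of the compounds shown alone.

The measured compounds:

Compound 1 `O=C(O)c1ccc2[nH]c(=O)c(=O)oc2c1`: 16000 nM
Compound 2 `O=c1[nH]c2cc([N+](=O)[O-])ccc2oc1=O`: 800 nM

Two compounds share a core and differ in the group attached to its carbocyclic ring. In a functional assay with Rattus norvegicus as the target (on this read-out higher numbers stand for weaker inhibition and lower numbers for stronger inhibition), compound 1 gives 16000 nM, and compound 2 gives 800 nM. Compound 2 therefore stands at the lower of the two numbers, and the gap between it and compound 1 lies beyond the scatter of repeated measurements, so compound 2 is the stronger inhibitor of the pair on this read-out.

Compound 3 `O=c1[nH]c2cc(C(F)(F)F)ccc2oc1=O` has not yet been measured. It differs from compound 2 in one place: trifluoromethyl in place of nitro on an aromatic carbon. For the measured compounds named here, no step between two measured compounds reports what this exchange does here, and the change from compound 1 to compound 2 concerns a different pair of groups, so it offers no direct guide.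

The expectation is that compound 3 keeps the order of magnitude of compound 2, with a modest shift toward a higher number in this assay, of the size a 1.9-fold higher number from compound 2 to compound 3 (0.27 log units; within the scatter), which may well fall within the scatter. Compound 3 is expected to give about 1500 nM, within a range from 400 nM to 6000 nM.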

Compound 3, half-maximal inhibitory concentration: 100000 nM
Compound 3: middle estimate off by 67-fold (1.82 log units), on the low side, and the stated range ends below it.
By their numbers in this assay, from the lowest: compound 2; then compound 1; then compound 3.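

In this assay, for the compounds shown here, trifluoromethyl in place of nitro on this aromatic carbon proves to be far from an interchangeable swap: the exchange gives a 130-fold higher number from compound 2 to compound 3 (2.10 log units; beyond the scatter) and thus a large step, the first reading of a single change on the shared core. It shows that the group on this carbon of the six-membered aromatic ring can by itself move the number a long way, and that nitro is much the better of these two groups on this read-out. The nitro that leaves carries hydrogen-bond acceptors and the trifluoromethyl that enters carries none, but that is a difference in count only, and no measurement on hand shows what lies behind the step.

The compounds shown leave open whether nitro is unusually favourable at this carbon or trifluoromethyl is unusually poor, as this single exchange has two ends and cannot separate them. A nitrile, an amine, a methyl group or plain hydrogen on the same carbon would show where other groups fall along this wide span, and whether the order seen here holds beyond this one pair.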